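From Isopropyl to Cyclopentyl on a Shared Diaryl Ether Core

This account rests on a few compounds, and the source may have more. Where it says the series, first, only, none or still open, it means among the compounds named here.

Compound 1, `COC(=O)c1ccc(OCCCCOc2ccc(C(=O)CC3CCCC3)c(C)c2C)cc1`: 14.1%
Compound 2, `Cc1c(OCCCCOc2ccc(C(=O)O)c(Cl)c2)ccc(C(=O)CC(C)C)c1C`: 33.1%

Of the compounds shown here, two have been measured in an assay on HEK293 cells for positive allosteric modulation of metabotropic glutamate receptor 2 (Rattus norvegicus), read by thallium flux, with a stated time of 2.5 min; a lower number here means a smaller maximal response, a higher number a larger maximal response. Compound 1 gives 14.1%, while compound 2 gives 33.1%, so compound 2 stands higher of the two, and its gap to compound 1 lies beyond the usual scatter. The two differ in several places at once, so their values alone do not show what any single change contributes.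

Compound 3, `Cc1c(OCCCCOc2ccc(C(=O)O)c(Cl)c2)ccc(C(=O)CC2CCCC2)c1C`, is not yet measured. It differs from compound 2 in one place: cyclopentyl in place of isopropyl on a saturated chain carbon bound to a carbonyl carbon. Because compound 2 already shows the higher value at 33.1%, and compound 1 carries the cyclopentyl group yet gives only 14.1% in a differently substituted setting, no direction is firmly indicated. The step is expected to be small in this assay, most likely within the scatter, with a slight lean upward; the estimated step is a number 4.9 percentage points higher from compound 2 to compound 3 (within the scatter). For compound 3 the expected maximal response in this assay is 38%, with a range from 15% to 65%.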

Compound 3, largest response reached (reported as percent of maximum), in percent of the reference or control that the assay uses: 61.8%
Estimate against measurement, compound 3: 23.8 percentage points below; the range from low to high includes it.
By their numbers in this assay, from the lowest: compound 1; then compound 2; then compound 3.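

In this assay, cyclopentyl in place of isopropyl on a saturated chain carbon bound to a carbonyl carbon reads as a number 28.7 percentage points higher from compound 2 to compound 3 (beyond the scatter) and so shows, with the rest of the structure held fixed, that the response at this place depends on the group it carries. The cyclopentyl group does not set the response alone: compound 1 and compound 3 both carry it, yet 4-carboxy-3-chlorophenyl in place of 4-(methoxycarbonyl)phenyl on an oxygen on a saturated carbon reads as a number 47.7 percentage points higher from compound 1 to compound 3 (beyond the scatter) and places compound 3 highest of the three, beyond the scatter from each of the others.

The compounds shown leave open whether the response keeps rising with ring size at this place, as cyclobutyl and cyclohexyl would test, or whether a ring is needed at all, as a straight pentyl chain would test. They also leave open how the carboxylic acid and the chlorine share the larger step, which 4-carboxyphenyl on the same oxygen would help to separate. No measurement at hand gives a reason for either step.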